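The source may hold more compounds than are shown below. What is called first, only, known or untested is meant among the compounds shown, and "the series" means these compounds.

Compound 1 `C#CCSc1nnc(CC)n1N1C(=O)c2ccccc2C1=O` in a functional assay on HepG2 cells (Homo sapiens) for cytotoxicity, read by MTT assay, with a stated time of 48 h; on this read-out lower numbers stand for stronger inhibition and higher numbers for weaker inhibition: > 200000 nM
Compound 2 `C=CCSc1nnc(CC)n1N1C(=O)c2ccccc2C1=O` in this assay: > 200000 nM

The value of compound 1 is a limit of the assay, not a number. The value of compound 2 is likewise only a limit. Both sit at the limit of > 200000 nM in this assay, at which 2 of the 2 values shown sit, so the step that the two limits leave unreadable from compound 1 to compound 2 cannot be read. Compound 3 `C=CCSc1nnc(CCC)n1N1C(=O)c2ccccc2C1=O` differs from compound 2 by methyl in place of hydrogen on a saturated chain carbon, two bonds along the chain from an aromatic carbon. For the measured compounds named here, the one measured step bears on this change but has no readable size, so no shift beyond the scatter can be expected from it. The expected change is a step that the limit leaves unreadable from compound 2 to compound 3. Compound 3 is estimated at 300000 nM, with a range from 120000 nM to 900000 nM, most likely again only a limit.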

Compound 3, half-maximal inhibitory concentration: > 200000 nM
Compound 3 gave a limit, no number; the forecaster's own chance of this, stated with the estimate: 85%; the middle value lies beyond the limit too.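

Compound 1, compound 2 and compound 3 all give only a limit, not a number, so no step between them can be read: the limit of > 200000 nM in this assay, at which 3 of the 3 values shown sit.

From the compounds shown here alone, whether any of the three compounds has a measurable effect on these cells, and whether either change shifts it, stays open.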